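Three compounds at the limit, and a fourth

A few compounds are considered here, and "the series" means these few. Any claim that something is new, unique, unknown or untested is made for them only; others in the source may bear on it.

compound 1 `COc1ccc(-c2cnc(NC(=O)c3ncc[nH]3)n2C)cc1`: > 100000 nM
compound 2 `COc1ccc(-c2cnc(NC(=O)c3cccnc3)n2C)cc1`: > 100000 nM
compound 3 `COc1ccc(-c2cnc(NC(=O)c3cnco3)n2C)cc1`: > 100000 nM

In a toxicity assay on THP-1 cells (Homo sapiens) for inhibition (a higher number here means that more compound is tolerated, a lower number that less compound is tolerated), compound 3 gives > 100000 nM and this is a limit of the assay, not a number. Going by the values given here, the whole series so far rests on the limit of > 100000 nM in this assay, at which 3 of the 3 values shown sit, and no compound has a true number yet.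

Compound 4 `COc1ccc(-c2cnc(NC(=O)c3cccc(Cl)c3)n2C)cc1` changes one group: 3-chlorophenyl takes the place of 1,3-oxazol-5-yl on a carbonyl carbon, with the counts 3-chlorophenyl in place of 1,3-oxazol-5-yl on a carbonyl carbon and the shared core stays the same.

Three measured steps change this same place: a step that the two limits leave unreadable from compound 1 to compound 2 and a step that the two limits leave unreadable from compound 1 to compound 3 and a step that the two limits leave unreadable from compound 2 to compound 3 and none has a readable size. None of them brought in a ring of carbon only, so they are a loose guide.

The expectation for compound 4 rests on compound 3 with its limit of > 100000 nM and so no clear step is expected in this assay unless a measurable number appears, which could only lie toward less compound being tolerated. The expected change is small, estimated as an at least 1.1-fold lower number from compound 3 to compound 4 (0.04 log units; that floor lies within the scatter) and uncertain. For compound 4 the estimate is 90000 nM with an expected range from 35000 nM to 150000 nM and the assay may well report only a limit again.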

Compound 4, half-maximal cytotoxic concentration: > 28000 nM
Compound 4: a limit, no number (the forecaster's own chance of this, stated with the estimate: 65%); the middle value is on the limit's open side.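

In this assay compound 4 gives > 28000 nM, which is a limit of the assay and not a number. The steps to compound 4 from compound 1, compound 2 and compound 3 cannot be read; all four compounds carry only limits. Still open, as far as these compounds go, is whether 3-chlorophenyl, compared with the other rings on the carbonyl carbon, changes how much compound is tolerated.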